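This account rests on a few compounds, and the source may have more. Where it says the series, first, only, none or still open, it means among the compounds named here.

In a functional assay on MCF7 cells (Homo sapiens) for inhibition, read by MTT assay, with a stated time of 96 h (on this read-out lower numbers stand for stronger inhibition of growth and higher numbers for weaker inhibition of growth), compound 1 `O=C(OCc1ccccc1)SCCCCCCNC(=O)c1cc(-c2ccncc2)n[nH]1` gives 8370 nM, and compound 2 `CC(C)C(=O)SCCCCCCNC(=O)c1cc(-c2ccncc2)n[nH]1` gives 15200 nM. Compound 3 `CCC(=O)SCCCCCCNC(=O)c1cc(-c2ccncc2)n[nH]1` has no number, only a limit of the assay, > 50000 nM. Compound 4 `CSCCCCCCNC(=O)c1cc(-c2ccncc2)n[nH]1` differs from it by methyl in place of propanoyl on a sulfur. The measured steps only vary the group on the carbonyl carbon. a 1.8-fold higher number from compound 1 to compound 2 (0.26 log units; within the scatter) stays within the scatter, whereas an at least 5.9-fold higher number from compound 1 to compound 3 (0.77 log units; beyond the scatter) and an at least 3.2-fold higher number from compound 2 to compound 3 (0.51 log units; beyond the scatter) go beyond it, towards weaker inhibition. None of them removes the carbonyl, so they bear on this change only indirectly. Growth inhibition is not expected to return, and the expected result is a number no higher from compound 3 to compound 4 (the limit leaves the size open), close to the limit. For compound 4 the estimate is 50000 nM, with an expected range of 20000 nM to 100000 nM.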

Compound 4, concentration for 50% growth inhibition: > 50000 nM
Compound 4: a limit, no number; the forecaster's own chance of this, stated with the estimate: 70%; the middle value lies on the limit itself.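

In this assay compound 4, which carries methyl on the sulfur and no carbonyl there, also gives only a limit, > 50000 nM. Methyl in place of the larger groups gives an at least 3.2-fold higher number from compound 2 to compound 4 (0.51 log units; beyond the scatter) and an at least 5.9-fold higher number from compound 1 to compound 4 (0.77 log units; beyond the scatter), so losing the carbonyl brings no measurable growth inhibition back. The step from compound 3 cannot be read, because both compounds rest on a limit: the limit of > 50000 nM in this assay, at which 2 of the 4 values shown sit.

As far as these compounds go, how far compound 4 lies beyond that limit stays open. So does whether a free thiol or an acetyl group on the sulfur would restore growth inhibition.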